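Series notes: aryl swap on the amine of compound 2

The source may hold more compounds than are shown below. What is called first, only, known or untested is meant among the compounds shown, and "the series" means these compounds.

Three members of the shared core have numbers in a functional assay on HT-29 cells (Homo sapiens) for cytotoxicity, read by sulforhodamine B assay; on this read-out lower numbers stand for stronger inhibition and higher numbers for weaker inhibition. Compound 1 `C=C1[C@@H](C/C=C2/C(=O)OC[C@H]2OC(C)=O)[C@]2(C)CC[C@@H](OC(C)=O)[C@@](C)(CO[Si](C)(C)C(C)(C)C)[C@H]2C[C@@H]1O` gives 9310 nM. Within the data shown here, compound 3 `C=C1CC[C@@H]2[C@](C)(CO[Si](C)(C)C(C)(C)C)[C@H](OC(C)=O)CC[C@@]2(C)[C@@H]1C/C=C1/C(=O)OC[C@H]1OC(C)=O` gives 4690 nM; the only single-point step measured so far, a 2.0-fold lower number from compound 1 to compound 3 (0.30 log units; within the scatter), concerns hydrogen in place of hydroxy on a saturated ring carbon. Compound 2 `C=C1[C@@H](OC(C)=O)C[C@@H]2[C@](C)(COC=O)[C@H](OC(C)=O)CC[C@@]2(C)[C@@H]1C[C@@H](Nc1ccccc1C(=O)O)C1=CCOC1=O` gives 28700 nM, the highest of the three numbers; compound 1 stands nearest and compound 3 furthest, and both gaps lie beyond the scatter.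

Compound 4 `C=C1[C@@H](OC(C)=O)C[C@@H]2[C@](C)(COC=O)[C@H](OC(C)=O)CC[C@@]2(C)[C@@H]1C[C@@H](Nc1cccc2ccccc12)C1=CCOC1=O` differs from compound 2 by naphthalen-1-yl in place of 2-carboxyphenyl on an amine nitrogen. Among the measured compounds shown here, no measured step in this set touches the amine substituent: the one step on record sits on a saturated ring carbon elsewhere in the core and is itself within the scatter, so it gives no guide to the size or direction of this change. With nothing to build on beyond the weak baseline of compound 2, a number in the same region is expected, with a wide range to allow for an unmeasured type of change. Compound 4 is therefore estimated at 22000 nM, with a range from 6000 nM to 70000 nM. The step this implies, a 1.3-fold lower number from compound 2 to compound 4 (0.12 log units; within the scatter), is expected to stay within the scatter.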

Compound 4, half-maximal inhibitory concentration: 8670 nM
For compound 4 the middle estimate is 2.5-fold (0.40 log units) above the measured one, and the stated range covers the measured number.
By their numbers in this assay, from the lowest: compounds 3, 4 and 1 (each within the scatter of the next); then compound 2.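

Among these compounds, the amine substituent is the first place in this set where a single change moves the number beyond the scatter: in this assay the swap gives a 3.3-fold lower number from compound 2 to compound 4 (0.52 log units; beyond the scatter) and so shows that this position is not silent, although the step is modest. The direction also shows that the 2-carboxyphenyl group is not needed to keep the number of compound 4 in this assay, as naphthalen-1-yl serves at least as well on the same amine nitrogen, with its saturated chain carbon unchanged. The swap changes several counted features at once, going from one aromatic ring to two and from one hydrogen-bond donor and acceptor to none, and nothing available gives a measured reason for the step.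

The compounds shown leave open whether the step follows the removal of the carboxylic acid or the arrival of the second aromatic ring, a question that a plain phenyl group on the same amine nitrogen would address. Also open, on these data alone, is how a methyl ester in place of the carboxylic acid, or naphthalen-2-yl in place of naphthalen-1-yl, would read in this assay on this core.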